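Removing the acetyl from a sesquiterpene lactone series

The source may hold more compounds than are shown below. What is called first, only, known or untested is meant among the compounds shown, and "the series" means these compounds.

Measured compounds:
compound 1 `C[C@@H]1C[C@H](O)C2=C(CO)C(=O)O/C2=C/[C@@]2(C)CC[C@]1(O)O2`: 24700 nM
compound 2 `C/C=C(\C)C(=O)O[C@H]1C[C@@H](C)[C@]2(OC)CC[C@](C)(/C=C3/OC(=O)C(COC(C)=O)=C31)O2`: 1200 nM
compound 3 `CC(=O)OCC1=C2/C(=C\[C@@]3(C)CC[C@](O)(O3)[C@H](C)C[C@@H]2O)OC1=O`: 2700 nM

In a functional assay on RAW264.7 cells (Mus musculus), read by Griess assay, with a stated time of 15 min (on this read-out higher numbers stand for weaker inhibition and lower numbers for stronger inhibition), compound 2 gives 1200 nM, the lowest of the three numbers. Compound 3 sits nearest to it, and compound 1 furthest away. The difference between the core of compound 2 and the core of compound 3 is not broken down here.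

One structural change is seen twice in this set. From compound 3 to compound 1 it is hydrogen in place of acetyl on an oxygen on a saturated carbon, and it made a step of a 9.1-fold higher number from compound 3 to compound 1 (0.96 log units; beyond the scatter). The same change, at the same kind of place, turns compound 2 into compound 4 `C/C=C(\C)C(=O)O[C@H]1C[C@@H](C)[C@]2(OC)CC[C@](C)(/C=C3/OC(=O)C(CO)=C31)O2`: hydrogen in place of acetyl on an oxygen on a saturated carbon.

Compound 4 has not yet been measured in this assay. Because the change from compound 3 to compound 1 gave a 9.1-fold higher number from compound 3 to compound 1 (0.96 log units; beyond the scatter), a step of similar size is expected for compound 4, that is a 9.2-fold higher number from compound 2 to compound 4 (0.96 log units; beyond the scatter). On that basis compound 4 is estimated at 11000 nM, with a plausible span from 3500 nM to 35000 nM.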

Compound 4, half-maximal inhibitory concentration: 2400 nM
For compound 4 the middle estimate is 4.6-fold (0.66 log units) above the measured one; measured number outside the range, below it.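

In this assay, hydrogen in place of acetyl on the core of compound 2 gives a 2.0-fold higher number from compound 2 to compound 4 (0.30 log units; within the scatter), so on this core the change from acetoxymethyl to hydroxymethyl has no effect that can be told from the scatter. The same change does not carry over at a fixed size between the two cores, since the steps differ: the same change on two cores in this assay, a 9.1-fold higher number (0.96 log units; beyond the scatter) from compound 3 to compound 1 and a 2.0-fold higher number (0.30 log units; within the scatter) from compound 2 to compound 4, 4.6-fold (0.66 log units) apart, beyond the scatter of two such steps. This rests on one pair for each core, and it does not show which of the differences between the two cores sets the steps apart, nor what size the step would take on any further core.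

Only acetyl and hydrogen appear on this oxygen in the compounds shown, so the effect of other groups there remains open. Whether a methyl ether or a longer acyl chain such as butanoyl would track the small step on the core of compound 2 or the larger one on the core of compound 3 cannot be told from this set.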